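Oxime to acetyl on a triazolylthioacetanilide: a single-point comparison

A few compounds are considered here, and "the series" means these few. Any claim that something is new, unique, unknown or untested is made for them only; others in the source may bear on it.

Measured compounds:
compound 1, `C=CCn1c(SCC(=O)Nc2ccc(C(C)=O)cc2)nnc1-c1ccccc1`: 70%
compound 2, `CCn1c(SCC(=O)Nc2ccc(/C(C)=N/O)cc2)nnc1-c1ccccc1`: 77%

Both compounds were tested in a functional assay on the whole organism (strain albino) for inhibition, with Rattus norvegicus as the target, read by paw edema, with stated times of 30 min and 4 h, at a dose of 0.28 mmol/kg by the oral route; a lower number here means less inhibition, a higher number more inhibition at the dose given (going by the name of the read-out). In this assay compound 1 gives 70%, and compound 2 gives 77%. Compound 2 thus sits alongside compound 1: the gap between the two numbers lies within the usual scatter, so neither number can be called the higher of the pair.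

Compound 3 is `CCn1c(SCC(=O)Nc2ccc(C(C)=O)cc2)nnc1-c1ccccc1`, not yet measured. It differs from compound 2 in one place: a group of 3 heavy atoms (2 carbon, 1 oxygen; no ring) in place of a group of 4 heavy atoms (2 carbon, 1 nitrogen, 1 oxygen; no ring), on an aromatic carbon. Compound 1 already carries the acetyl group and shows no separation from compound 2 beyond the scatter, so no step beyond the scatter is expected in this assay for this change in either direction. The expected step from compound 2 to compound 3 is a number 5 percentage points lower from compound 2 to compound 3 (within the scatter). Compound 3 is therefore estimated at 72%, with a range from 58% to 84%.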

Compound 3, a percentage reported as inhibition, in the whole organism at one dose (the size of the read-out at that dose, not a potency): 69%
Beside the measured number, compound 3's estimate is 3 percentage points above it; the range from low to high includes it.
By their numbers in this assay, from the lowest: compounds 3, 1 and 2 (each within the scatter of the next).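

With the chain on the aromatic nitrogen held fixed, the change on the aromatic carbon can now be read alone: in this assay, exchanging the oxime for acetyl, which removes the hydrogen-bond donor of the leaving group, gives a number 8 percentage points lower from compound 2 to compound 3 (within the scatter). With acetyl held fixed, methyl in place of vinyl on the saturated chain carbon bound to the aromatic nitrogen gives a number 1 percentage points lower from compound 1 to compound 3 (within the scatter), so neither single change separates these compounds at this dose. No measurement at hand bears on why these steps are this small.

From the compounds shown here alone, whether a carboxylic acid or an amine on that aromatic carbon, or a longer chain on the aromatic nitrogen, would also stay within the scatter remains open. With a single dose, the potency of these compounds also remains open.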